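Propanoyl to acetyl on a chromene dimer core

This account rests on a few compounds, and the source may have more. Where it says the series, first, only, none or still open, it means among the compounds named here.

Measured compounds:
- compound 1, `CCC(=O)C1=C(O)C(C)(C)C(O)=C(CC2=C(O)C(C)(C)C(O)=C(C(=O)CC)C2=O)C1=O`, > 50 ug/mL
- compound 2, `CCC(=O)C1=C(O)C(C)(C)C(O)=C(Cc2c(O)c3c(c(C(=O)CC)c2O)OC(C)(C)C=C3)C1=O`, 6.6 ug/mL
- compound 3, `CC(=O)C1=C(O)C(C)(CC=C(C)C)C(O)=C(Cc2c(O)c(CC=C(C)C)c(O)c(C(C)=O)c2O)C1=O`, 42 ug/mL

In a functional assay on cells (Cancer cell lines, Homo sapiens) for cytotoxicity, with a stated time of 72 h (on this read-out lower numbers stand for an effect already at smaller amounts and higher numbers for an effect only at larger amounts of compound), compound 1 gives > 50 ug/mL, which is a limit of the assay and not a number. In this assay compound 3 gives 42 ug/mL. Compound 2 gives 6.6 ug/mL in this assay, the lowest of the two numbers shown, and its gap to compound 3 lies beyond the scatter.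

Compound 4, `CCC(=O)C1=C(O)C(C)(C)C(O)=C(Cc2c(O)c3c(c(C(C)=O)c2O)OC(C)(C)C=C3)C1=O`, differs from compound 2 in one place: hydrogen in place of methyl on a saturated chain carbon bound to a carbonyl carbon. The same difference, cut one bond further out, reads propanoyl to acetyl. Among the measured compounds shown here, no measured pair in this set carries this change, so the size of the step rests on the change alone. A small step is expected in this assay, if any, and not beyond the scatter. For compound 4 the expected value in this assay is 8 ug/mL, within 3 ug/mL to 20 ug/mL, which would mean a step of a 1.2-fold higher number from compound 2 to compound 4 (0.08 log units; within the scatter).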

Compound 4, concentration for half-maximal effect: 6.3 ug/mL
Estimate against measurement, compound 4: 1.3-fold (0.10 log units) above; the measured number falls inside the stated range.
By their numbers in this assay, from the lowest: compounds 4 and 2 (each within the scatter of the next); then compound 3. At a limit, above all of these: compound 1.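

In this assay, the exchange of propanoyl for acetyl gives a 1.0-fold lower number from compound 2 to compound 4 (0.02 log units; within the scatter), and this pair is the only direct test of the change among the compounds shown. It shows that, on this core, hydrogen in place of methyl on a saturated chain carbon bound to a carbonyl carbon produces no difference that can be read beyond the scatter. Nothing measured here accounts for the match between the two compounds.

On these data alone, whether a longer chain such as butanoyl, or a carboxylic acid or an amine at this place, would keep the number in the same range remains open. As far as these compounds go, it is also open whether the same exchange would read alike on the other propanoyl group, which compound 4 still carries.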